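Adding a Second Chloro Group to Compound 1

The source may report more compounds than this note shows. Statements on the series, on what has been measured and on what is new or still open speak of the compounds shown alone.

Three compounds sharing a formylated, thione-bearing core have been examined in a functional assay on NCI/ADR-RES cells (Homo sapiens) for inhibition, read by sulforhodamine B assay, with a stated time of 48 h; on this read-out lower numbers stand for stronger inhibition of growth and higher numbers for weaker inhibition of growth. Compound 1 `O=CN1CCN(c2ccc(Cl)cc2)C1=S` gives 36500 nM in this assay. Compound 2 `COc1cc(C(=O)N2CCN(C=O)C2=S)cc(OC)c1OC` gives 36100 nM, and compound 3 `O=CN1CCN(C(=O)c2ccco2)C1=S` gives 24500 nM. The three numbers lie close together: compound 1 is not separated from compound 2 or from compound 3 by more than the usual scatter of repeated measurements, so no order among them can be read from these data.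

Compound 4 `O=CN1CCN(c2ccc(Cl)c(Cl)c2)C1=S` has not yet been measured in this assay. It differs from compound 1 in a single place: chloro in place of hydrogen on an aromatic carbon. Among the measured compounds shown here, no pair of measured compounds shows the effect of such a change, so nothing in the numbers above points in either direction. The account therefore expects no step beyond the scatter in this assay, with at most a slight move toward a lower number, which here would stand for somewhat stronger inhibition of growth.

On that basis compound 4 is estimated at 27000 nM in this assay, within a range from 10000 nM to 65000 nM, which amounts to an expected step of a 1.4-fold lower number from compound 1 to compound 4 (0.13 log units; within the scatter).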

Compound 4, concentration for 50% growth inhibition: 32900 nM
For compound 4 the middle estimate is 1.2-fold (0.09 log units) below the measured one; the range from low to high includes it.
By their numbers in this assay, from the lowest: compounds 3, 4, 2 and 1 (each within the scatter of the next).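

In this assay, placing chloro in place of hydrogen on an aromatic carbon, ortho to a chloro group and meta to a group of 8 heavy atoms, gives a step of a 1.1-fold lower number from compound 1 to compound 4 (0.05 log units; within the scatter). This is the first single-place comparison among the compounds shown, and it shows that a second chloro group at this position does not shift growth inhibition beyond the scatter of repeated measurements, so compound 4 cannot be told apart from compound 1 on this read-out. Nothing measured here bears on why the change leaves the number where it is.

The compounds shown test only chloro at this one position, so they leave open whether a different group placed there, such as an amine, a carboxylic acid or a methoxy group, would produce a step beyond the scatter. They also leave open what happens when the existing chloro group of compound 1 is replaced by hydrogen, and whether that group contributes anything to the growth inhibition seen on these cells.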